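Notes on replacing 4-fluorophenyl with thiophen-2-yl

The compounds below may be only part of what the source reports. "The series", "measured", "known", "first", "only" and "open" are said of these compounds alone.

Measured in a functional assay on HT-29 cells (Homo sapiens) for antiproliferative activity, read by MTT assay, with a stated time of 24 h; on this read-out higher numbers stand for weaker inhibition and lower numbers for stronger inhibition:
compound 1 `COc1ccc(C(=O)/C=C/c2ccc(F)cc2)c2c1C=CC(C)(C)O2` gives > 10000 nM, a limit of the assay.
compound 2 `COc1ccc(C(=O)/C=C/c2ccc3ccccc3n2)c2c1C=CC(C)(C)O2` gives 3790 nM.
compound 3 `COc1ccc(C(=O)/C=C/c2ccc(OC)c(OC)c2OC)c2c1C=CC(C)(C)O2` gives > 10000 nM, a limit of the assay.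

Compound 1 stands at the limit of > 10000 nM in this assay, at which 2 of the 3 values shown sit, so for it only a limit is known, and among the three only compound 2 yields a number. Compound 4 `COc1ccc(C(=O)/C=C/c2cccs2)c2c1C=CC(C)(C)O2` differs from compound 1 by thiophen-2-yl in place of 4-fluorophenyl on a double-bonded chain carbon bound to a double-bonded chain carbon. Going by the values given here, no step between measured compounds is available to scale this change, and the shared core is unchanged. Compound 4 is expected to give 8000 nM, with a range of 2000 nM to 30000 nM. The step of an at least 1.2-fold lower number from compound 1 to compound 4 (0.09 log units; that floor lies within the scatter) is expected to stay within the scatter, with a fair chance that compound 4 again returns only a limit.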

Compound 4, half-maximal inhibitory concentration: > 10000 nM
Compound 4: only a limit was reported; the forecaster's own chance of this, stated with the estimate: 55%; at least 1.2-fold (0.09 log units) between middle value and limit.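

No step can be read from compound 1 to compound 4, because both return only a limit: the limit of > 10000 nM in this assay, at which 3 of the 4 values shown sit.

The compounds shown leave open how thiophen-2-yl and 4-fluorophenyl compare on the shared core.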